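The source may report more compounds than this note shows. Statements on the series, on what has been measured and on what is new or still open speak of the compounds shown alone.

Compound 1 `N#Cc1ccc2nc(-c3cccnc3)n(C3CC3)c2c1` carries a cyano group on the shared core, and in an assay on V79 cells for inhibition of cytochrome P450 11B2, mitochondrial (Homo sapiens), read by HTRF, with a stated time of 1 h (on this read-out higher numbers stand for weaker inhibition and lower numbers for stronger inhibition), compound 1 gives 1.2 nM. Of the two numbers recorded in this assay, compound 1 stands at the higher one. Compound 3 `N#Cc1cc2c(cc1F)nc(-c1cccnc1)n2C1CC1`, which adds a fluoro in place of hydrogen on an aromatic carbon, gives 0.6 nM in this assay, and the step of a 2.0-fold lower number from compound 1 to compound 3 (0.30 log units; within the scatter) lies within the scatter. Compound 2 `Fc1ccc2nc(-c3cccnc3)n(C3CCC3)c2c1` differs from compound 1 in more than one place. In this assay compound 2 reaches only a limit, > 5000 nM, so no number is known for it.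

Compound 4 `COc1ccc2nc(-c3cccnc3)n(C3CC3)c2c1` has not yet been measured. Compared with compound 1 it changes in one place: methoxy in place of cyano on an aromatic carbon. Among the measured compounds shown here, no measured step exchanges the cyano group by itself, so no step bears directly on this change; the one measured step, between compound 1 and compound 3, kept the cyano group and stayed within the scatter. The number for compound 4 in this assay is therefore expected to shift by a 25-fold higher number from compound 1 to compound 4 (1.40 log units; beyond the scatter), toward weaker inhibition, with wide uncertainty. Compound 4 is estimated at 30 nM, within a range from 3 nM to 300 nM.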

Compound 4, half-maximal inhibitory concentration: 24 nM
Compound 4: the middle estimate sits 1.3-fold (0.10 log units) above what was measured; the range from low to high includes it.
By their numbers in this assay, from the lowest: compounds 3 and 1 (each within the scatter of the next); then compound 4. At a limit, above all of these: compound 2.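

The step from cyano to methoxy is the only one shown that exchanges the group on this aromatic carbon, and in this assay it gives a 20-fold higher number from compound 1 to compound 4 (1.30 log units; beyond the scatter), so this position responds clearly to which group it carries, unlike the added fluoro, which stayed within the scatter while the cyano group was kept. The size of the step also stands out against what is counted for the two groups: each has 2 heavy atoms, no ring, 0 hydrogen-bond donors, 1 hydrogen-bond acceptor and no net charge, so none of these counts separates cyano from methoxy. Nothing measured among these compounds gives a reason for the step.

From the compounds shown here alone, whether an amine, a carboxylic acid or a longer chain such as ethoxy on this carbon would fall nearer compound 1 or compound 4 remains open, as does whether methoxy would have the same effect alongside the added fluoro of compound 3. Compound 2 reaches only a limit, > 5000 nM, and differs from compound 1 in more than one place, so it settles neither question.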